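Dropping One Chlorine from a Dichlorophenyl Urea Tail

The source may hold more compounds than are shown below. What is called first, only, known or untested is meant among the compounds shown, and "the series" means these compounds.

Three urea compounds that share one core were tested in a functional assay on MOLT-4 cells (Homo sapiens) for inhibition, read by sulforhodamine B assay, with a stated time of 48 h, tested at 0.01 uM; a higher number here means a weaker effect of the compound at the concentration tested, a lower number a stronger effect. Compound 1 `COc1cc(Cl)cc(-c2nn(-c3cccc(NC(=O)Nc4ccc(Cl)c(C(F)(F)F)c4)c3)cc2-c2ccncc2)c1` gives 99%. Compound 2 `COc1cc(Cl)cc(-c2nn(-c3cccc(NC(=O)Nc4cc(C(F)(F)F)cc(C(F)(F)F)c4)c3)cc2-c2ccncc2)c1` gives 94%. Compound 3 `COc1cc(Cl)cc(-c2nn(-c3cccc(NC(=O)Nc4ccc(Cl)c(Cl)c4)c3)cc2-c2ccncc2)c1` gives 99%, level with compound 1 at the digits shown and together the highest of the three numbers, while compound 2 sits a little lower but within the scatter. Compound 4 `COc1cc(Cl)cc(-c2nn(-c3cccc(NC(=O)Nc4cccc(C(F)(F)F)c4)c3)cc2-c2ccncc2)c1` differs from compound 3 by 3-(trifluoromethyl)phenyl in place of 3,4-dichlorophenyl on an amide-type nitrogen. Among the compounds with values here, only one measured step touches this part of the molecule: no change at the digits printed from compound 1 to compound 3 (within the scatter), which lies within the scatter. No step beyond the scatter is therefore expected from compound 3 to compound 4, roughly a number 2 percentage points lower from compound 3 to compound 4 (within the scatter). Compound 4 is estimated at 97%, with a range from 88% to 102%.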

Compound 4, a percentage reported as activity, at one concentration (the size of the read-out at that concentration, not a potency): 95%
Estimate against measurement, compound 4: 2 percentage points above; the measured number falls inside the stated range.
By their numbers in this assay, from the lowest: compounds 2, 4, 1 and 3 (each within the scatter of the next).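

In this assay the aromatic ring on the amide-type nitrogen keeps its read-out when a group is lost: hydrogen in place of chloro gives a number 4 percentage points lower from compound 1 to compound 4 (within the scatter) and hydrogen in place of trifluoromethyl gives a number 1 percentage points higher from compound 2 to compound 4 (within the scatter). Exchanging 3,4-dichlorophenyl for 3-(trifluoromethyl)phenyl gives a number 4 percentage points lower from compound 3 to compound 4 (within the scatter). A single trifluoromethyl therefore cannot be told apart here from the rings carrying two groups, and no evidence is available to explain this. As far as these compounds go, whether plain phenyl, or an amine or a carboxylic acid on this ring, would shift the number remains open.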